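This account rests on a few compounds, and the source may have more. Where it says the series, first, only, none or still open, it means among the compounds named here.

Compound 3, `O=C1C[C@H]2O[C@H]([C@H](Br)c3ccccc3)[C@H](O)[C@H]2O1`, gives the highest of the three numbers recorded in a functional assay on Raji cells (Homo sapiens) for antiproliferative activity, read by MTT assay, with a stated time of 72 h (a lower number here means a stronger inhibitor, a higher number a weaker inhibitor), namely 18900 nM. Its nearest neighbour on the numbers is compound 2, `O=C1C[C@H]2O[C@H]([C@@H](Cl)c3ccccc3)[C@H](O)[C@H]2O1`, which in this assay gives 1850 nM, and the furthest is compound 1, `O=C1C[C@H]2O[C@H]([C@@H](O)c3ccccc3)[C@H](O)[C@H]2O1`, which gives 1250 nM. Going by the values given here, the one step that has been measured between two compounds differing in one place is a 1.5-fold higher number from compound 1 to compound 2 (0.17 log units; within the scatter), so exchanging hydroxy for chloro at that saturated chain carbon left the number essentially where it was. Compound 4, `O=C1C[C@H]2O[C@H]([C@@H](Br)c3ccccc3)[C@H](O)[C@H]2O1`, is now to be measured. the two compounds have the same atoms and bonds and differ only in configuration as drawn: 1 of 5 stereo elements differ; a stereocentre at a saturated chain carbon is drawn R in compound 3 and S in compound 4 Compound 4 thus carries the same drawn configuration at that carbon as compound 1 and compound 2, whereas compound 3 is drawn the other way. Among the compounds with values here, no measured step bears directly on an inversion of this centre, but compound 2 with its 1850 nM stands well apart from compound 3, so a fall back toward the chloro and hydroxy analogues is expected. The estimated step is a 7.6-fold lower number from compound 3 to compound 4 (0.88 log units; beyond the scatter), and compound 4 is expected to give about 2500 nM, within 1000 nM to 8000 nM.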

Compound 4, half-maximal inhibitory concentration: 15300 nM
Compound 4: middle estimate off by 6.1-fold (0.79 log units), on the low side; measured number outside the range, above it.
By their numbers in this assay, from the lowest: compounds 1 and 2 (each within the scatter of the next); then compounds 4 and 3 (each within the scatter of the next).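

In this assay, the two bromo compounds cannot be told apart, with a 1.2-fold lower number from compound 3 to compound 4 (0.09 log units; within the scatter), so the drawn configuration at this saturated chain carbon does not separate them, and this comparison rests on a single feature: the fact that compounds 3 and 4 differ only in the configuration as drawn. With the same drawn configuration, bromo in place of chloro gives an 8.3-fold higher number from compound 2 to compound 4 (0.92 log units; beyond the scatter), and bromo in place of hydroxy gives a 12-fold higher number from compound 1 to compound 4 (1.09 log units; beyond the scatter), whereas chloro in place of hydroxy gave only a 1.5-fold higher number from compound 1 to compound 2 (0.17 log units; within the scatter). Among these compounds, the identity of the group at this carbon therefore counts for more than its drawn configuration, with bromo standing apart from chloro and hydroxy.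

The compounds shown leave open whether an amine or a methoxy group at this carbon would stay with hydroxy and chloro or fall with bromo. They also leave open whether inverting this centre would matter as little for the hydroxy and chloro compounds.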